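The source may report more compounds than this note shows. Statements on the series, on what has been measured and on what is new or still open speak of the compounds shown alone.

In an ADME assay on L02 cells (Homo sapiens) for antiproliferative activity, read by MTT assay, with a stated time of 48 h (on this read-out lower numbers stand for stronger inhibition and higher numbers for weaker inhibition), compound 1 (`C=CCN(C)C(=O)c1ccc(C(CC)(CC)c2ccc(OCCC(O)(CC)CC)c(C)c2)n1CC`) gives 1190 nM as a measured number. Compound 2 (`CCn1c(C(=O)Nc2ccc(OC(F)(F)F)cc2)ccc1C(CC)(CC)c1ccc(OCCC(O)(CC)CC)c(C)c1`) holds only a limit, > 50000 nM (a limit). Compound 3 (`CCn1c(C(=O)Nc2cccc(C(F)(F)F)c2)ccc1C(CC)(CC)c1ccc(OCCC(O)(CC)CC)c(C)c1`) also holds only a limit, > 50000 nM (a limit), so it has no measured number to start from. The change to compound 4 (`CCC(C)C(NC(=O)c1ccc(C(CC)(CC)c2ccc(OCCC(O)(CC)CC)c(C)c2)n1CC)C(=O)OC`) is a group of 9 heavy atoms (7 carbon, 2 oxygen; no ring) in place of a group of 10 heavy atoms (7 carbon, 3 fluorine; one six-membered aromatic ring of carbon only), on an amide-type nitrogen and leaves the shared core untouched. Within the data shown here, two measured steps bear on it, an at least 42-fold higher number from compound 1 to compound 2 (1.62 log units; beyond the scatter) and an at least 42-fold higher number from compound 1 to compound 3 (1.62 log units; beyond the scatter) (both large and beyond the scatter), while a step that the two limits leave unreadable from compound 2 to compound 3 gives no size. Among these three compounds, the two with a six-membered aromatic ring in this group sit at the limit. Compound 1, without such a ring, reads 1190 nM in this assay. Compound 4 also has no ring in this group, so a move towards compound 1 is expected, but probably only part of the way, as its group differs from that of compound 1. The step expected is an at least 6.2-fold lower number from compound 3 to compound 4 (0.79 log units; beyond the scatter) towards stronger inhibition, an estimate set against a limit. For compound 4 the estimated value is 8000 nM with an expected range from 1500 nM to 40000 nM in this assay.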

Compound 4, half-maximal inhibitory concentration: > 50000 nM
Compound 4: no number, only a limit (the forecaster's own chance of this, stated with the estimate: 20%); at least 6.2-fold (0.79 log units) between middle value and limit.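

In this assay compound 4 holds only a limit, > 50000 nM, so removing the six-membered aromatic ring from the group on the amide-type nitrogen does not by itself yield a measured number. Among these compounds, the lack of a ring in this group therefore does not set the one measured compound apart, as an at least 42-fold higher number from compound 1 to compound 4 (1.62 log units; beyond the scatter) shows; compounds 2, 3 and 4 all keep the amide hydrogen, whereas compound 1 carries allyl and methyl on that nitrogen. The steps among compound 2, compound 3 and compound 4 cannot be read, and all three sit at the same limit: the limit of > 50000 nM in this assay, at which 3 of the 4 values shown sit.

Still open, on these data alone, is where a dimethylamino or methylamino group on the carbonyl carbon would read against compound 1. Also open, as far as these compounds go, is whether a carboxylic acid in place of the methyl ester of compound 4 would give a measured number.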